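The source may hold more compounds than are shown below. What is called first, only, known or untested is meant among the compounds shown, and "the series" means these compounds.

Measured in a physicochemical assay for solubility; a lower number here means a less soluble compound, a higher number a more soluble compound:
Compound 1 `CNC(=O)c1cc(C(=O)NC2CC2)cn(Cc2cccc(F)c2)c1=O`: >= 133 ug/mL
Compound 2 `CNC(=O)c1cc(C(=O)NC2CC2)cn(CC2CCCCC2)c1=O`: >= 148 ug/mL
Compound 3 `CNC(=O)c1cc(C(=O)NC2CC2)cn(Cc2ccccc2F)c1=O`: >= 145 ug/mL
Compound 4 `CNC(=O)c1cc(C(=O)NC2CC2)cn(Cc2cccc3cc[nH]c23)c1=O`: not yet measured

Compound 3 stands at >= 145 ug/mL, and this reading is a limit, not a number. The readings of compound 1 and compound 2 are limits too. Compound 4 carries 1H-indol-7-yl in place of 2-fluorophenyl on a saturated chain carbon bound to an aromatic nitrogen. Changes at that same place are known only as a step that the two limits leave unreadable from compound 1 to compound 3, a step that the two limits leave unreadable from compound 2 to compound 3 and a step that the two limits leave unreadable from compound 1 to compound 2. None of them gives a size or a direction to carry over, so no step beyond the scatter is expected in this assay. The estimate is an at least 1.1-fold lower number from compound 3 to compound 4 (0.06 log units; that floor lies within the scatter). For compound 4 the expected value is 125 ug/mL, with an estimated range from 50 ug/mL to 170 ug/mL.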

Compound 4, solubility: >= 144 ug/mL
Compound 4: only a limit was reported; the forecaster's own chance of this, stated with the estimate: 50%; at least 1.1-fold (0.06 log units) between middle value and limit.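

Going by these compounds alone, the readings of compound 1, compound 2, compound 3 and compound 4 in this assay are all limits, and no step from any of the first three to compound 4 can be read. The compounds shown leave open whether the group on the saturated chain carbon changes this read-out at all.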